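Methoxy Added to an Oxime Analogue: Expected Potency

The source may report more compounds than this note shows. Statements on the series, on what has been measured and on what is new or still open speak of the compounds shown alone.

Compound 1 `Cn1c(=O)c2[nH]c(SCC(=O)c3ccccc3)nc2n(C)c1=O` carries a thioether chain ending in a carbonyl attached to a phenyl ring. In a functional assay on MCF7 cells (Homo sapiens) for inhibition, read by MTT assay, with a stated time of 48 h (on this read-out lower numbers stand for stronger inhibition and higher numbers for weaker inhibition), compound 1 gives 5100 nM. Compound 2 `COc1ccc(C(=O)CSc2nc3c([nH]2)c(=O)n(C)c(=O)n3C)cc1` differs from it in one place, (methoxy in place of hydrogen on an aromatic carbon), and this change gave a 1.5-fold higher number from compound 1 to compound 2 (0.17 log units; within the scatter). In this assay compound 2 gives 7600 nM. Compound 3 `Cn1c(=O)[nH]c2nc(SC/C(=N/O)c3ccccc3)[nH]c2c1=O` has an oxime in place of the carbonyl and a differently arranged core; the difference between the two cores is not broken down here. In this assay compound 3 gives 4300 nM, a number within the scatter of both compound 1 and compound 2, so no order among the three can be claimed.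

Compound 4 `COc1ccc(/C(CSc2nc3[nH]c(=O)n(C)c(=O)c3[nH]2)=N\O)cc1` has not yet been measured. It differs from compound 3 in one place, (methoxy in place of hydrogen on an aromatic carbon), the same change, at the same place, as that from compound 1 to compound 2. Among the measured compounds shown here, the step from compound 3 to compound 4 is expected to be a 1.4-fold higher number from compound 3 to compound 4 (0.14 log units; within the scatter), because a 1.5-fold higher number from compound 1 to compound 2 (0.17 log units; within the scatter) is the only measured example of this change. Compound 4 is therefore expected to give 6000 nM in this assay, with the likely range running from 3000 nM to 12000 nM.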

Compound 4, half-maximal inhibitory concentration: 1800 nM
Estimate against measurement, compound 4: 3.3-fold (0.52 log units) above; the measured number lies below the stated range.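

In this assay the methoxy group on the oxime compounds gave a 2.4-fold lower number from compound 3 to compound 4 (0.38 log units; beyond the scatter) and so a modest gain in inhibition, whereas on the carbonyl compounds the same change made no readable difference. This does not show what sets the two pairs apart: they differ both in the oxime that replaces the carbonyl and in the arrangement of the core, and the data do not separate these two differences. Set side by side, the two steps disagree, so in this series a methoxy result from one core cannot simply be carried over to the other: the same change on two cores in this assay, a 1.5-fold higher number (0.17 log units; within the scatter) from compound 1 to compound 2 and a 2.4-fold lower number (0.38 log units; beyond the scatter) from compound 3 to compound 4, 3.6-fold (0.55 log units) apart, beyond the scatter of two such steps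

The compounds shown leave open whether the gain on the oxime compounds is particular to methoxy or would also appear with another group in the same place, such as a chlorine atom or a hydroxyl group. They also leave open whether it would persist with the oxime on the core of compound 1, which would tell the effect of the oxime from that of the core.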